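The source may report more compounds than this note shows. Statements on the series, on what has been measured and on what is new or still open speak of the compounds shown alone.

Compound 3 `COc1cc(C2=NN(C(C)=O)C(c3cccc(F)c3)O2)cc(OC)c1OC` stands highest of the three numbers measured in a functional assay on BGC-823 cells (Homo sapiens) for antiproliferative activity, read by MTT assay, tested at 1 uM (on this read-out lower numbers stand for a weaker effect and higher numbers for a stronger effect at the one concentration tested), with compound 3 giving 14.7%; compound 1 `COc1cc(C2=NN(C(C)=O)C(c3cccc(OC)c3OC)O2)cc(OC)c1OC` gives 3.8% and compound 2 `COc1cc(C2=NN(C(C)=O)C(c3ccc(Cl)c(Cl)c3)O2)cc(OC)c1OC` gives -0.8%. Compound 4 `COc1cc(C2=NN(C(C)=O)C(c3ccc(F)c(F)c3)O2)cc(OC)c1OC` differs from compound 3 by fluoro in place of hydrogen on an aromatic carbon, which read one bond further out is 3-fluorophenyl to 3,4-difluorophenyl. Within the data shown here, no measured step adds a single group to the phenyl on the saturated ring carbon; the nearest are a number 15.5 percentage points higher from compound 2 to compound 3 (beyond the scatter) and a number 10.9 percentage points higher from compound 1 to compound 3 (beyond the scatter), while a number 4.6 percentage points lower from compound 1 to compound 2 (within the scatter). Both measured steps into compound 3 came from lower values, so a small drop, or no step beyond the scatter, is expected in this assay, estimated as a number 4.7 percentage points lower from compound 3 to compound 4 (within the scatter). Compound 4 is thus expected at 10%, with a range of -2% to 22%.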

Compound 4, a percentage reported as inhibition, at one concentration (the size of the read-out at that concentration, not a potency): 18.3%
The estimate for compound 4 lay 8.3 percentage points below the measured number; low and high end bracket the measured number.
By their numbers in this assay, from the lowest: compounds 2 and 1 (each within the scatter of the next); then compounds 3 and 4 (each within the scatter of the next).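

In this assay, fluoro in place of hydrogen, ortho to a fluoro group, stays within the scatter (a number 3.6 percentage points higher from compound 3 to compound 4 (within the scatter)), so 3,4-difluorophenyl reads alike with 3-fluorophenyl here. The pair of halogens does matter: 3,4-difluorophenyl in place of 3,4-dichlorophenyl (a number 19.1 percentage points higher from compound 2 to compound 4 (beyond the scatter)) and in place of 2,3-dimethoxyphenyl (a number 14.5 percentage points higher from compound 1 to compound 4 (beyond the scatter)) both lie beyond the scatter. Nothing available explains these steps.

Open, on these data alone, is how an amine, a carboxylic acid or a longer chain on this phenyl would read. Open too is whether any of these compounds differ in potency, as the read-out comes from one concentration.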